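Phenyl substitution on the core of compound 1

A few compounds are considered here, and "the series" means these few. Any claim that something is new, unique, unknown or untested is made for them only; others in the source may bear on it.

Measured so far:
compound 1 `COc1cccc(Cc2ccnn(CC(=O)Nc3ccc(Br)cc3)c2=O)c1`: 14600 nM
compound 2 `CCc1cc(Cc2cccc(OC)c2)c(=O)n(CC(=O)Nc2ccc(I)cc2)n1`: > 50000 nM

Of the compounds shown here, two have been tested in an assay on HL-60 cells for agonist activity at N-formyl peptide receptor 3 (Homo sapiens), read by calcium flux; a higher number here means that more compound is needed for the effect, a lower number that less compound is needed. Compound 1 gives 14600 nM and is the only one with an actual half-maximal effective concentration; it is a weak agonist on this number. Compound 2 reaches only the upper limit of this assay, > 50000 nM, so no number is known for it. Compound 2 differs from compound 1 in more than one place, so no single step can be read from the pair; the limit of > 50000 nM in this assay, at which 1 of the 2 values shown sits, is all that is known for it.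

Compound 3 `COc1cccc(Cc2cc(-c3ccccc3)nn(CC(=O)Nc3ccc(Br)cc3)c2=O)c1` is not yet measured. It differs from compound 1 by phenyl in place of hydrogen on an aromatic carbon, the new group sitting on the core of compound 1 at the place described above.

Among the measured compounds shown here, no measured step exists for this kind of change, so the expectation rests on compound 1 alone. The value for compound 3 is expected at 5000 nM, within 1000 nM to 30000 nM. This estimate means a step of a 2.9-fold lower number from compound 1 to compound 3 (0.47 log units; beyond the scatter), expected to be a modest gain beyond the scatter, though a limit cannot be excluded.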

Compound 3, half-maximal effective concentration: > 50000 nM
Compound 3 gave a limit, no number (the forecaster's own chance of this, stated with the estimate: 20%); at least 10-fold (1.00 log units) between middle value and limit.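

In this assay, among the compounds shown here, phenyl in place of hydrogen on the aromatic carbon next to the ring nitrogen gives an at least 3.4-fold higher number from compound 1 to compound 3 (0.53 log units; beyond the scatter), the first step that can be read from a change in one place. At this position, then, the added phenyl costs agonist potency relative to the unsubstituted carbon of compound 1, and it does not deliver a gain. Compound 3 gives > 50000 nM, which is a limit of the assay and not a number, so the step has a lower bound only and its true size stays unknown: the limit of > 50000 nM in this assay, at which 2 of the 3 values shown sit.

What the compounds shown leave open is whether this carbon rejects substitution in general or phenyl in particular, since a single group at one position cannot separate the two cases. A methyl group, an amine or a carboxylic acid at the same carbon, each on the otherwise unchanged core of compound 1, would show whether any substituent here can hold or improve on compound 1 and its 14600 nM value.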